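The source may hold more compounds than are shown below. What is called first, only, known or untested is meant among the compounds shown, and "the series" means these compounds.

Compound 1 `O=[N+]([O-])c1cn2c(n1)OC[C@@H](OCc1cccc(-c3ccc(F)cc3)c1)C2` and compound 2 `COc1ccc(-c2cccc(CO[C@@H]3COc4nc([N+](=O)[O-])cn4C3)c2)cc1F` share a core and differ in one place. In an ADME assay on Vero cells (Chlorocebus sabaeus) for cytotoxicity, with a stated time of 72 h (a higher number here means a weaker inhibitor, a lower number a stronger inhibitor), compound 1 gives > 128000 nM, which is a limit of the assay and not a number. In this assay compound 2 gives > 128000 nM, also a limit of the assay. The change between them is 3-fluoro-4-methoxyphenyl in place of 4-fluorophenyl on an aromatic carbon and its step is a step that the two limits leave unreadable from compound 1 to compound 2. The step stays unreadable because of the limit of > 128000 nM in this assay, at which 3 of the 3 values shown sit.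

Compound 3 `O=[N+]([O-])c1cn2c(n1)OC[C@@H](OCc1csc(-c3ccc(F)cc3)n1)C2` rests on another core; the difference between the two cores is not broken down here. In this assay compound 3 gives > 128000 nM, again a limit of the assay.

Compound 4 `COc1ccc(-c2nc(CO[C@@H]3COc4nc([N+](=O)[O-])cn4C3)cs2)cc1F` is not yet measured in this assay. It arises from compound 3 by the same kind of change as compound 2 from compound 1, namely (3-fluoro-4-methoxyphenyl in place of 4-fluorophenyl on an aromatic carbon), but the place differs: in compound 1 the group sits on an aromatic carbon of a six-membered aromatic ring of carbon only, meta to a large group, whereas in compound 3 it sits on an aromatic carbon of a five-membered aromatic ring with 1 nitrogen and 1 sulfur, next to the ring nitrogen, next to the ring sulfur, two ring bonds from the ring atom that bears a large group. Going by the values given here, with every value so far a limit, the step from compound 3 to compound 4 is expected to be a step that the limit leaves unreadable from compound 3 to compound 4. Compound 4 is expected to give about 150000 nM in this assay, between 80000 nM and 400000 nM.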

Compound 4, half-maximal inhibitory concentration: > 128000 nM
Compound 4: a limit, no number (the forecaster's own chance of this, stated with the estimate: 85%); the middle value does not contradict the limit.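

In this assay compound 4 gives > 128000 nM, a limit of the assay and not a number. No size can be read for the change from compound 3 to compound 4, because both compounds sit at the same limit: the limit of > 128000 nM in this assay, at which 4 of the 4 values shown sit.

The compounds shown leave open whether 3-fluoro-4-methoxyphenyl in place of 4-fluorophenyl alters the read-out in this assay at all, on either core.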